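The source may report more compounds than this note shows. Statements on the series, on what has been measured and on what is new or still open speak of the compounds shown alone.

Compound 1 `CC(C)Oc1cc(Oc2ccc(S(C)(=O)=O)cc2)cc(-c2nccc(=O)[nH]2)c1`: 24 10^-6 cm/s
Compound 2 `CC(C)Oc1cc(Oc2cnc(C(=O)N(C)C)nc2)cc(-c2nccc(=O)[nH]2)c1`: 7.1 10^-6 cm/s
Compound 3 `CC(C)Oc1cc(Oc2ccc(S(C)(=O)=O)cc2)cc(-c2ncc(C(C)C)c(=O)[nH]2)c1`: "not determined" (no result reported)

In an ADME assay on MDCK-II cells (Canis lupus familiaris) for permeability (a lower number here means that the compound crosses the layer more slowly, a higher number that the compound crosses the layer faster), compound 2 has the lower of the two available numbers, while compound 1 stands at 24 10^-6 cm/s and the gap lies beyond the usual scatter. Compound 4 `C[C@@H](CO)Oc1cc(Oc2cnc(C(=O)N(C)C)nc2)cc(-c2nccc(=O)[nH]2)c1` differs from compound 2 by hydroxy in place of hydrogen on a saturated chain carbon, two bonds along the chain from an oxygen on an aromatic ring. Isopropoxy thus becomes 1-(hydroxymethyl)ethoxy. For the measured compounds named here, no measured pair shows this change, so its size rests on judgement alone, and a moderate fall beyond the scatter is expected. The estimated step is a 2.4-fold lower number from compound 2 to compound 4 (0.37 log units; beyond the scatter). For compound 4 the expected value is 3 10^-6 cm/s, within an estimated range of 1.2 10^-6 cm/s to 6.5 10^-6 cm/s.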

Compound 4, apparent permeability: 0.81 10^-6 cm/s
Beside the measured number, compound 4's estimate is 3.7-fold (0.57 log units) above it; measured number outside the range, below it.
By their numbers in this assay, from the lowest: compound 4; then compound 2; then compound 1.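

In this assay, a single added oxygen atom that turns isopropoxy into 1-(hydroxymethyl)ethoxy gives an 8.8-fold lower number from compound 2 to compound 4 (0.94 log units; beyond the scatter) while the rest of the molecule stays the same. For the compounds shown here, this is the first pair that isolates one change at this position, since compound 1 and compound 2 differ elsewhere, and it shows that the number responds strongly to this small edit. No measurement shown accounts for the size of this step. From the compounds shown here alone, whether a methoxy group or an amine in place of the hydroxy would give a similar step stays open, as does the size of the same change on compound 1.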